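The source may report more compounds than this note shows. Statements on the series, on what has been measured and on what is new or still open speak of the compounds shown alone.

Of the compounds shown here, two built on one shared core have so far been tested in a functional assay on HL-60 cells (Homo sapiens) for antiproliferative activity, with a stated time of 24 h; on this read-out higher numbers stand for weaker inhibition and lower numbers for stronger inhibition. Compound 1 `NC(=O)c1c(NC(=O)c2ccccc2Cl)sc2c1CCN(Cc1ccc(Cl)cc1)C2` gives 22500 nM. Compound 2 `NC(=O)c1c(NC(=O)c2ccccc2Cl)sc2c1CCN(Cc1cc(Cl)cc(Cl)c1)C2` gives 15800 nM; on the bare numbers it stands lowest of the two, yet the step of a 1.4-fold lower number from compound 1 to compound 2 (0.15 log units; within the scatter) shows that the two values cannot be told apart. Compound 3 `NC(=O)c1c(NC(=O)c2ccccc2Cl)sc2c1CCN(C(=S)Nc1ccccc1)C2` is not yet measured. It differs from compound 2 by a group of 9 heavy atoms (7 carbon, 1 nitrogen, 1 sulfur; one six-membered aromatic ring of carbon only) in place of a group of 9 heavy atoms (7 carbon, 2 chlorine; one six-membered aromatic ring of carbon only), on an amine nitrogen in a ring. For the measured compounds named here, the only measured step exchanges one chlorinated benzyl group for another on the same ring nitrogen and stays within the scatter, so it does not tell how replacing the whole benzyl group by the entering group will behave. No step beyond the scatter is therefore expected, and the range must be wide. Compound 3 is estimated at 20000 nM in this assay, between 5000 nM and 80000 nM, which corresponds to an expected step of a 1.3-fold higher number from compound 2 to compound 3 (0.10 log units; within the scatter).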

Compound 3, half-maximal inhibitory concentration: 5940 nM
The estimate for compound 3 lay 3.4-fold (0.53 log units) above the measured number; low and high end bracket the measured number.
By their numbers in this assay, from the lowest: compound 3; then compounds 2 and 1 (each within the scatter of the next).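

For the compounds shown here, replacing the whole benzyl group on the amine nitrogen in a ring, rather than only moving or adding chlorine on it, gives the first changes beyond the scatter in this assay: a 2.7-fold lower number from compound 2 to compound 3 (0.42 log units; beyond the scatter), and a 3.8-fold lower number from compound 1 to compound 3 (0.58 log units; beyond the scatter). Both steps are modest, but they show that the read-out responds to what sits at this position and that a benzyl group is not required there, since compound 3 has the lowest number of the three. No available data bear on why the number falls.

The entering group differs from both benzyl groups in several features at once, so the sulfur, the nitrogen and its hydrogen cannot be told apart in their contributions. On these data alone, it remains open how a urea, with oxygen in place of the sulfur, or a chlorine on the entering group's aromatic ring would behave.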